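The compounds below may be only part of what the source reports. "The series", "measured", "known", "first", "only" and "open" are said of these compounds alone.

- compound 1 `COc1ccc(-c2nnc(SCCCN3CCN(c4nc5ccccc5o4)CC3)o2)cc1` value 66100 nM
- compound 2 `Brc1ccc(-c2nnc(SCCCN3CCN(c4nc5ccccc5o4)CC3)o2)cc1` value 67500 nM

Both values come from a functional assay on HepG2 cells (Homo sapiens) for inhibition, read by MTT assay, with a stated time of 72 h (a higher number here means a weaker inhibitor, a lower number a stronger inhibitor), and lie within the scatter of each other, so compound 2 stands level with compound 1. Compound 3 `CC(C)(C)Oc1ccc(-c2nnc(SCCCN3CCN(c4nc5ccccc5o4)CC3)o2)cc1` has tert-butoxy in place of bromo on an aromatic carbon. Among the compounds with values here, one measured step bears on this change, bromo in place of methoxy on an aromatic carbon (a 1.0-fold higher number from compound 1 to compound 2 (0.01 log units; within the scatter)), and it stayed within the scatter. A single step is thin evidence, but no step beyond the scatter is expected. The expected step is small (a 1.2-fold lower number from compound 2 to compound 3 (0.09 log units; within the scatter)). Compound 3 is expected at 55000 nM (estimated range 20000 nM to 110000 nM).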

Compound 3, half-maximal inhibitory concentration: 121000 nM
The estimate for compound 3 lay 2.2-fold (0.34 log units) below the measured number; the whole stated range lies below it.
By their numbers in this assay, from the lowest: compounds 1, 2 and 3 (each within the scatter of the next).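

In this assay, tert-butoxy, with 5 heavy atoms against the single atom of bromo, gives a 1.8-fold higher number from compound 2 to compound 3 (0.25 log units; within the scatter), and tert-butyl in place of methyl on the oxygen gives a 1.8-fold higher number from compound 1 to compound 3 (0.26 log units; within the scatter). Both steps stay within the scatter, so even this larger group on the aromatic carbon produces no change that can be told from the scatter. No available evidence accounts for these numbers. Going by these compounds, whether an amine or a carboxylic acid at this position would move the number beyond the scatter remains open.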